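The source may report more compounds than this note shows. Statements on the series, on what has been measured and on what is new or still open speak of the compounds shown alone.

In an ADME assay on L929 cells (Mus musculus) for cytotoxicity (a higher number here means a weaker inhibitor, a lower number a stronger inhibitor), compound 2 `C#CCCCCOc1ccc(-c2oc3ccccc3c(=O)c2OCc2cccc(C(=O)OC)c2)cc1` gives > 100000 nM, which is a limit of the assay and not a number. In this assay, compound 1 `COC(=O)c1cccc(COc2c(-c3ccc(OCCCCc4cn(CCOCCO)nn4)cc3)oc3ccccc3c2=O)c1` gives 13300 nM. Compound 3 `COC(=O)c1cccc(COc2c(-c3ccc(OCCCCc4cn(Cc5ccccc5)nn4)cc3)oc3ccccc3c2=O)c1` carries 1-benzyl-1H-1,2,3-triazol-4-yl in place of the ethynyl of compound 2: 1-benzyl-1H-1,2,3-triazol-4-yl in place of ethynyl on a saturated chain carbon, four bonds along the chain from an oxygen on an aromatic ring. Within the data shown here, the one measured step that bears on this is an at least 7.5-fold higher number from compound 1 to compound 2 (0.87 log units; beyond the scatter), which lost a five-membered aromatic ring with 3 hetero atoms. Compound 3 regains that ring, so a step of similar size towards a lower number is expected. The estimated change is an at least 7.6-fold lower number from compound 2 to compound 3 (0.88 log units; beyond the scatter). For compound 3 the expected value is 13000 nM, with an estimated range of 4000 nM to 60000 nM.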

Compound 3, half-maximal inhibitory concentration: > 100000 nM
Compound 3 was reported as a limit (the forecaster's own chance of this, stated with the estimate: 15%); middle value at least 7.6-fold (0.88 log units) from the limit.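

The five-membered aromatic ring with 3 hetero atoms does not bring the number down by itself: with that ring kept, this assay shows an at least 7.5-fold higher number from compound 1 to compound 3 (0.87 log units; beyond the scatter). What changes here is the group on the saturated chain carbon bound to an aromatic nitrogen, with phenyl in place of (2-hydroxyethoxy)methyl. The step between the ethynyl compound and its benzyl triazole partner cannot be read, because both values are limits: the limit of > 100000 nM in this assay, at which 2 of the 3 values shown sit.

Still open, on these data alone, is whether an amine or a carboxylic acid on that chain carbon would give a number as low as compound 1 does.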